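The source may report more compounds than this note shows. Statements on the series, on what has been measured and on what is new or still open speak of the compounds shown alone.

Measured compounds:
- compound 1, `COc1ccc(C(=O)Nc2cccc(Cl)c2Cl)cc1OC1CCCC1`: in an assay on isolated protein for inhibition of phosphodiesterase 4A (Sus scrofa) (on this read-out lower numbers stand for stronger inhibition and higher numbers for weaker inhibition), compound 1 reaches only the assay limit > 200000 nM.
- compound 2, `COc1ccc(C(=O)Nc2ncccc2C)cc1OC1CCCC1`: in this assay compound 2 gives 3100 nM.
- compound 3, `COc1ccc(C(=O)Nc2c(C)nsc2C)cc1OC1CCCC1`: in this assay compound 3 gives 500 nM.

Compound 3 stands at the lowest number of the two actual numbers; compound 2 is the nearest, and the step of a 6.2-fold lower number from compound 2 to compound 3 (0.79 log units; beyond the scatter) lies beyond the scatter. Compound 1 sits at a limit only (the limit of > 200000 nM in this assay, at which 1 of the 3 values shown sits). The other steps, an at least 64-fold lower number from compound 1 to compound 2 (1.80 log units; beyond the scatter) and an at least 400-fold lower number from compound 1 to compound 3 (2.60 log units; beyond the scatter), are large, and every measured step exchanges the whole group on the amide-type nitrogen.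

Compound 4, `COc1ccc(C(=O)Nc2c(C)nsc2C#N)cc1OC1CCCC1`, differs from compound 3 by cyano in place of methyl on an aromatic carbon. Among the measured compounds shown here, no measured step changes a single substituent within a group that stays otherwise the same, so none bears directly on this change. Without such a precedent, no step beyond the scatter is expected in this assay in either direction. Compound 4 is expected to give 450 nM, with a range from 90 nM to 2500 nM. The expected step of a 1.1-fold lower number from compound 3 to compound 4 (0.05 log units; within the scatter) is therefore estimated to stay within the scatter.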

Compound 4, half-maximal inhibitory concentration: 200 nM
The estimate for compound 4 lay 2.3-fold (0.35 log units) above the measured number, within the range that was stated.
By their numbers in this assay, from the lowest: compound 4; then compound 3; then compound 2. At a limit, above all of these: compound 1.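

In this assay, the step of a 2.5-fold lower number from compound 3 to compound 4 (0.40 log units; beyond the scatter) is the first shown to change a single substituent within an otherwise unchanged group, and it shows that this aromatic carbon next to the ring sulfur responds to cyano in place of methyl. The 5-cyano-3-methyl-1,2-thiazol-4-yl group also extends the lead over 3-methylpyridin-2-yl, with a 16-fold lower number from compound 2 to compound 4 (1.19 log units; beyond the scatter), leaving compound 4 with the lowest number of the series, its steps to all others being beyond the scatter. The step of an at least 1000-fold lower number from compound 1 to compound 4 (3.00 log units; beyond the scatter) starts from a limit and not from a number: the limit of > 200000 nM in this assay, at which 1 of the 4 values shown sits.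

Only methyl and cyano are shown on this carbon, so it remains open how a chlorine, an amine or a carboxylic acid there would read. Going by these compounds, the methyl group two ring bonds away stays the same in compound 3 and compound 4, so the response to replacing it with cyano or ethyl also remains open.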